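The source may report more compounds than this note shows. Statements on the series, on what has been measured and on what is new or still open speak of the compounds shown alone.

Working notes on the series. In a functional assay on NALM-6 cells (Homo sapiens) for cytotoxicity, read by MTT assay, with a stated time of 48 h (a lower number here means a stronger inhibitor, a higher number a weaker inhibitor), compound 1 `O=C(Nc1cc(C(F)(F)F)ccc1Nc1ccc(Br)cc1)c1ccncc1` gives 51900 nM, the highest of the two numbers in hand. Compound 3 `O=C(Nc1cc(C(F)(F)F)ccc1Nc1ccc(Br)cc1)c1ccccc1` gives 6000 nM in this assay, and the single-point step an 8.7-fold lower number from compound 1 to compound 3 (0.94 log units; beyond the scatter) shows what phenyl in place of pyridin-4-yl on the carbonyl carbon does. Within the data shown here, compound 2 `O=C(Nc1cc(C(F)(F)F)ccc1N1CCCCC1)c1cccnc1Cl` is reported in this assay as "not active" (no number reported); it differs from compound 1 in more than one place, so no step to it is counted.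

Compound 4 `O=C(Nc1cc(C(F)(F)F)ccc1N1CCCC1)c1ccncc1` differs from compound 1 by pyrrolidin-1-yl in place of (4-bromophenyl)amino on an aromatic carbon. Among the measured compounds shown here, no measured step touches this position directly. For the measured compounds named here, the only related observation is compound 2, which carries a saturated nitrogen ring at the same place and comes out as "not active" (no number reported); compound 1 itself sits at the weak end with 51900 nM. The expectation is therefore a number no lower than that of compound 1, most likely weaker or beyond reach, with the step of a 1.7-fold higher number from compound 1 to compound 4 (0.24 log units; within the scatter) estimated. For compound 4 the estimate in this assay is 90000 nM, range 30000 nM to 300000 nM.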

Compound 4, half-maximal inhibitory concentration: "not active" (no number reported)
Compound 4: no number reported, so the estimate cannot be set against anything.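

Among these compounds, compound 4 is reported as "not active" without a number in this assay, so no step from compound 1 to compound 4 can be read. No measured evidence bears on this result. The compounds shown leave open whether any replacement of (4-bromophenyl)amino in compound 1 retains a measurable number.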